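A few compounds are considered here, and "the series" means these few. Any claim that something is new, unique, unknown or untested is made for them only; others in the source may bear on it.

In an ADME assay on HepG2 cells (Homo sapiens) for cytotoxicity, with a stated time of 72 h (on this read-out higher numbers stand for an effect only at larger amounts of compound and lower numbers for an effect already at smaller amounts), compound 1 `Cc1cc(NC(=O)Nc2ccc(C(C)(C)C)cc2)c2ccccc2n1` gives 17000 nM, compound 2 `CSc1ccc(NC(=O)Nc2cc(C)nc3ccccc23)cc1` gives 16000 nM, and compound 3 `Cc1cc(NC(=O)Nc2ccc(OC(F)(F)F)cc2)c2ccccc2n1` gives 15000 nM. Compound 3 therefore stands level with the other two, within the scatter of both. Compound 4 `COc1ccc(NC(=O)Nc2cc(C)nc3ccccc23)cc1` differs from compound 3 by methyl in place of trifluoromethyl on an oxygen on an aromatic ring. Within the data shown here, no measured step makes this exact change. The nearest evidence comes from group exchanges on an aromatic carbon: a 1.1-fold lower number from compound 1 to compound 2 (0.03 log units; within the scatter), a 1.1-fold lower number from compound 1 to compound 3 (0.05 log units; within the scatter) and a 1.1-fold lower number from compound 2 to compound 3 (0.03 log units; within the scatter), each within the scatter. No step beyond the scatter is therefore expected, and the expected size is a 1.2-fold higher number from compound 3 to compound 4 (0.08 log units; within the scatter). For compound 4 the estimate is 18000 nM, with an expected range of 9000 nM to 35000 nM.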

Compound 4, half-maximal effective concentration: > 25000 nM
Compound 4 ended at the assay's limit; the forecaster's own chance of this, stated with the estimate: 15%; at least 1.3-fold (0.14 log units) between middle value and limit.
By their numbers in this assay, from the lowest: compounds 3, 2 and 1 (each within the scatter of the next). At a limit, above all of these: compound 4.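

In this assay compound 4, with methoxy, is the only compound shown whose read-out ends at a limit rather than a number: the limit of > 25000 nM in this assay, at which 1 of the 4 values shown sits. Only floors can be read, and each lies within the scatter: an at least 1.6-fold higher number from compound 3 to compound 4 (0.22 log units; that floor lies within the scatter) and an at least 1.5-fold higher number from compound 2 to compound 4 (0.19 log units; that floor lies within the scatter) and an at least 1.4-fold higher number from compound 1 to compound 4 (0.16 log units; that floor lies within the scatter). The change from trifluoromethoxy to methoxy may therefore be small or much larger, whereas the three earlier groups gave numbers within the scatter of one another.

The compounds shown leave open how far the read-out of compound 4 lies past the limit. They also leave open whether an amine or a carboxylic acid at this position would give a measurable number.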